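Replacing the thiophene of compound 1 with an acyclic oxime ether

This account rests on a few compounds, and the source may have more. Where it says the series, first, only, none or still open, it means among the compounds named here.

The measured compounds and their values:
Compound 1, `c1csc(-c2ccccc2NCC2=NCCN2)c1`, 2.24 nM
Compound 2, `c1ccc(-c2cnoc2)c(NCC2=NCCN2)c1`, 45.7 nM
Compound 3, `c1ccc(-c2cnccn2)c(NCC2=NCCN2)c1`, 4.57 nM

In a functional assay for activation of Alpha-1A adrenergic receptor (Homo sapiens), read by calcium flux (on this read-out higher numbers stand for an effect only at larger amounts of compound and lower numbers for an effect already at smaller amounts), compound 1 gives the lowest number of the three. Its nearest neighbour is compound 3, a step of a 2.0-fold higher number from compound 1 to compound 3 (0.31 log units; beyond the scatter); the furthest is compound 2, a step of a 20-fold higher number from compound 1 to compound 2 (1.31 log units; beyond the scatter). Compound 4, `CO/N=C/c1ccccc1NCC1=NCCN1`, has not yet been measured. It differs from compound 1 in one place: a group of 4 heavy atoms (2 carbon, 1 nitrogen, 1 oxygen; no ring) in place of a group of 5 heavy atoms (4 carbon, 1 sulfur; one five-membered aromatic ring with 1 hetero atom), on an aromatic carbon.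

Among the measured compounds shown here, two measured steps bear on this change, since both replace the same thiophen-2-yl on the same aromatic carbon: a 20-fold higher number from compound 1 to compound 2 (1.31 log units; beyond the scatter) and a 2.0-fold higher number from compound 1 to compound 3 (0.31 log units; beyond the scatter). Both went toward higher numbers, one modestly and one by a large amount. For the measured compounds named here, in compound 4 the entering group is not a ring at all, and no measured step tells how an acyclic group fares at this position. A step toward a higher number is therefore expected, probably between the two measured ones, and compound 4 is estimated at a 5.4-fold higher number from compound 1 to compound 4 (0.73 log units; beyond the scatter).

Compound 4 is thus expected to give about 12 nM, within a range of 2.5 nM to 60 nM.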

Compound 4, half-maximal effective concentration: 51.3 nM
Compound 4: middle estimate off by 4.3-fold (0.63 log units), on the low side; the range from low to high includes it.
By their numbers in this assay, from the lowest: compound 1; then compound 3; then compounds 2 and 4 (each within the scatter of the next).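

In this assay, the open-chain oxime ether gives a 23-fold higher number from compound 1 to compound 4 (1.36 log units; beyond the scatter) and also an 11-fold higher number from compound 3 to compound 4 (1.05 log units; beyond the scatter) at this aromatic carbon. Against the 1,2-oxazol-4-yl ring it gives a 1.1-fold higher number from compound 2 to compound 4 (0.05 log units; within the scatter) and so stands level with that ring, which shows that a group with no ring can land at the same number as a ring here. Among these four compounds, having a ring therefore does not by itself decide where a compound falls, since compound 2 carries a ring and still sits with compound 4.

On these data alone, it remains open whether a plain phenyl ring or an amine on the same aromatic carbon would stay near compound 1 or fall with compound 4. As far as these compounds go, it is equally open whether a longer chain in place of the methyl of the oxime ether would move the number.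

Nothing in the data shown bears on why these groups fall where they do.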